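Three Measured Bis-Benzylidene Ketones and One Unmeasured Cousin

The source may hold more compounds than are shown below. What is called first, only, known or untested is meant among the compounds shown, and "the series" means these compounds.

Measured compounds, with their numbers in a functional assay on HT-1080 cells (Homo sapiens) for cytotoxicity, read by MTT assay, with a stated time of 72 h; a lower number here means a stronger inhibitor, a higher number a weaker inhibitor:
- compound 1, `COc1ccccc1/C=C1\CCC/C(=C\c2ccc(OC)c(OC)c2)C1=O`, gives 8100 nM
- compound 2, `COc1cccc(/C=C2\CCC/C(=C\c3ccc(OC)c(OC)c3)C2=O)c1`, gives 4600 nM
- compound 3, `COc1ccc(/C=C2\CCC/C(=C\c3ccc(OC)c(OC)c3)C2=O)c(OC)c1`, gives 17100 nM

All three share one core, and they differ only in how one of the two aromatic rings is decorated. Compound 1 and compound 2 are built from the same atoms joined differently: the difference is 3-methoxyphenyl in place of 2-methoxyphenyl on a double-bonded chain carbon bound to a double-bonded ring carbon. The step of a 1.8-fold lower number from compound 1 to compound 2 (0.25 log units; within the scatter) is one the scatter of this assay could produce on its own, so the two values are best read as alike.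

Compound 3 takes compound 1 and adds a group: methoxy in place of hydrogen on an aromatic carbon. Here the step is a 2.1-fold higher number from compound 1 to compound 3 (0.32 log units; beyond the scatter), a modest rise in the number, meaning compound 3 is a somewhat weaker inhibitor than compound 1 in this assay.

Compound 4, `COc1cc(/C=C2\CCC/C(=C\c3ccc(OC)c(OC)c3)C2=O)cc(OC)c1`, has not yet been measured. It relates to compound 2 as compound 3 relates to compound 1: methoxy in place of hydrogen on an aromatic carbon. The two changes are the same kind of change, but not the same, since the place differs: in compound 3 the new methoxy sits para to a large group, while in compound 4 it sits meta to a large group. Going by the values given here, with only one earlier step of this kind to go on, compound 4 is expected to follow compound 3 in direction, with a step of about a 2.0-fold higher number from compound 2 to compound 4 (0.29 log units; within the scatter) from compound 2, because a 2.1-fold higher number from compound 1 to compound 3 (0.32 log units; beyond the scatter) is the one precedent available. The expected value for compound 4 in this assay is 9000 nM, with a plausible range from 4000 nM to 20000 nM.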

Compound 4, half-maximal inhibitory concentration: 2600 nM
Estimate against measurement, compound 4: 3.5-fold (0.54 log units) above; the measured number lies below the stated range.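

In this assay, the new step is a 1.8-fold lower number from compound 2 to compound 4 (0.25 log units; within the scatter), so these two values are best read as alike, and the added methoxy leaves the number about where it was on this core. Set beside the earlier case, the same written change does not carry over from one core to another as a fixed step, so a result seen on one compound is a poor guide to the next: the same change on two cores in this assay, a 2.1-fold higher number (0.32 log units; beyond the scatter) from compound 1 to compound 3 and a 1.8-fold lower number (0.25 log units; within the scatter) from compound 2 to compound 4, 3.7-fold (0.57 log units) apart, beyond the scatter of two such steps

What this does not show is why the two cases part. Going by these compounds alone, the new methoxy sits in a different place in each case (in compound 4 it is meta to a large group, and meta to a methoxy group), so the core and the place change together, and with only one pair on each side the two cannot be told apart.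

As far as these compounds go, it stays open whether a different group on this ring, such as a hydroxy group, a chlorine atom or an amine, would behave differently from core to core. From the compounds shown here alone, the other aromatic ring is the same in all four compounds, so the effect of changing its two methoxy groups, for example to ethoxy groups, also remains open.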